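Notes on the step from compound 2 to compound 3

The source may hold more compounds than are shown below. What is called first, only, known or untested is meant among the compounds shown, and "the series" means these compounds.

In a functional assay on L1210 cells (Mus musculus) for inhibition, read by MTT assay, with a stated time of 72 h (a lower number here means a stronger inhibitor, a higher number a weaker inhibitor), compound 2 (`COc1cc(NC(C)CCCNC(=O)NNC(=O)Nc2ccc(Cl)cc2)c2ncccc2c1`) holds the higher of the two numbers at 58000 nM, while compound 1 (`COc1cc(NC(C)CCCNC(=O)Nc2cccc(F)c2)c2ncccc2c1`) gives 19000 nM. Compound 3 (`COc1cc(NC(C)CCCNC(=O)Nc2ccc(F)cc2)c2ncccc2c1`) has 4-fluorophenyl in place of ((4-chlorophenyl)carbamoyl)amino on an amide-type nitrogen. Among the compounds with values here, one measured step bears on this change: a 3.1-fold higher number from compound 1 to compound 2 (0.48 log units; beyond the scatter). That modest step introduced the same ((4-chlorophenyl)carbamoyl)amino group in place of 3-fluorophenyl, so a reverse step of similar size is expected in this assay. The expected step is a 2.6-fold lower number from compound 2 to compound 3 (0.42 log units; beyond the scatter). The estimate for compound 3 is 22000 nM, with an expected range of 10000 nM to 48000 nM.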

Compound 3, half-maximal inhibitory concentration: 18000 nM
The estimate for compound 3 lay 1.2-fold (0.09 log units) above the measured number; the measured number falls inside the stated range.
By their numbers in this assay, from the lowest: compounds 3 and 1 (each within the scatter of the next); then compound 2.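

In this assay, 4-fluorophenyl and 3-fluorophenyl on the amide-type nitrogen cannot be told apart, with a 1.1-fold lower number from compound 1 to compound 3 (0.02 log units; within the scatter). Replacing ((4-chlorophenyl)carbamoyl)amino with 4-fluorophenyl gives a 3.2-fold lower number from compound 2 to compound 3 (0.51 log units; beyond the scatter), so compound 2 now stands apart from two fluorophenyl compounds rather than one. No measurement available here accounts for this difference. Still open, on these data alone, is how an unsubstituted phenyl, a 4-chlorophenyl or a benzyl group on this nitrogen would compare. Also open, as far as these compounds go, is whether a shorter or longer chain between the core and the urea would change these numbers.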